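Extending the acid chain of compound 1: an expectation

The source may report more compounds than this note shows. Statements on the series, on what has been measured and on what is new or still open speak of the compounds shown alone.

Measured compounds:
- compound 1 `O=C(O)COc1cccc(CCCn2cc(C(c3ccccc3)c3ccccc3)ccc2=O)c1`: in an in vivo ADME assay on the whole organism (strain Hartley) for pharmacokinetics, with Cavia porcellus as the target, at a dose of 10 mg/kg by the oral route (on this read-out lower numbers stand for lower exposure and higher numbers for higher exposure at the dose given), compound 1 gives 1850 nM
- compound 2 `COc1ccc(C(=O)N(CCCc2cccc(OCC(=O)O)c2)CCC(c2ccccc2)c2ccccc2)cc1`: in this assay compound 2 gives 74.4 nM

Of the two measured compounds, compound 1 stands highest in this assay; compound 2 sits well below it, and that gap is beyond the usual scatter of repeated runs. The two differ in several places at once, so their values say only what they show, not which part of the structure matters.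

Compound 3 `O=C(O)CCCOc1cccc(CCCn2cc(C(c3ccccc3)c3ccccc3)ccc2=O)c1` has not yet been measured. It keeps the shared core of compound 1 and changes only the acid side chain: 2-carboxyethyl in place of carboxy on a saturated chain carbon bound to an oxygen on an aromatic ring. Among the measured compounds shown here, no pair of measured compounds shows this change alone, so there is no measured step to lean on.

For the measured compounds named here, with a single, modest change of chain length and no precedent, the step from compound 1 to compound 3 in this assay is expected to be small, possibly none beyond the scatter, with a slight lean downward. Compound 3 is therefore estimated at 1300 nM (range 400 nM to 4500 nM), a step of a 1.4-fold lower number from compound 1 to compound 3 (0.15 log units; within the scatter) that is expected rather than known.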

Compound 3, maximal plasma concentration: 1040 nM
The estimate for compound 3 lay 1.3-fold (0.10 log units) above the measured number; measured number inside the range.
By their numbers in this assay, from the lowest: compound 2; then compounds 3 and 1 (each within the scatter of the next).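

Among the compounds shown here, compound 1 and compound 3 are the first measured pair that differ in one place only, so this change can now be read on its own: 2-carboxyethyl in place of carboxy on a saturated chain carbon bound to an oxygen on an aromatic ring gives, in this assay, a 1.8-fold lower number from compound 1 to compound 3 (0.25 log units; within the scatter), and the two numbers cannot be told apart from repeat runs of the same compound. Seen from one bond further out, the acid side chain goes from carboxymethoxy to 3-carboxypropoxy with the shared core untouched, and at this place the longer chain leaves oral exposure in the guinea pig without a change that this read-out can resolve. Nothing in the data shown accounts for this outcome.

One pair on one core leaves open whether the same lengthening would behave alike on the core of compound 2, and whether a still longer chain would also leave the number within the scatter. It also leaves open what happens at this place when an amide or an amine stands in place of the carboxylic acid at the end of the chain.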